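Extending the methylamino chain: compound 3 to compound 4

This account rests on a few compounds, and the source may have more. Where it says the series, first, only, none or still open, it means among the compounds named here.

- compound 1 `CNCC(=O)Nc1cc(OC)ccc1C(=O)c1ccc2c(c1)C=CC(C)(C)O2`: 850 nM
- compound 2 `COc1ccc(C(=O)c2cc(OC)c(OC)c(OC)c2)c(NC(=O)CO)c1`: 100 nM
- compound 3 `CNCC(=O)Nc1cc(OC)ccc1C(=O)c1cc(OC)c(OC)c(OC)c1`: 580 nM

All values come from a functional assay on A2780 cells (Homo sapiens) for antiproliferative activity, read by MTT assay, with a stated time of 48 h; a lower number here means a stronger inhibitor, a higher number a weaker inhibitor. Compound 3 lies within the scatter of compound 1 and well above compound 2, with a 5.8-fold higher number from compound 2 to compound 3 (0.76 log units; beyond the scatter). Compound 4 `CCNCC(=O)Nc1cc(OC)ccc1C(=O)c1cc(OC)c(OC)c(OC)c1` carries methyl in place of hydrogen on a saturated chain carbon bound to an amine nitrogen, so methylamino becomes ethylamino. Going by the values given here, the only measured step on this chain is a 5.8-fold higher number from compound 2 to compound 3 (0.76 log units; beyond the scatter), and it is a different exchange, so no measured step gives this size directly. A small change in this assay, with no clear direction, is expected: a 1.1-fold higher number from compound 3 to compound 4 (0.05 log units; within the scatter). For compound 4 the estimated value is 650 nM, with an expected range of 280 nM to 1500 nM.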

Compound 4, half-maximal inhibitory concentration: 950 nM
The estimate for compound 4 lay 1.5-fold (0.16 log units) below the measured number, and the stated range covers the measured number.
By their numbers in this assay, from the lowest: compound 2; then compounds 3, 1 and 4 (each within the scatter of the next).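

In this assay, methyl in place of hydrogen on a saturated chain carbon bound to an amine nitrogen gives a 1.6-fold higher number from compound 3 to compound 4 (0.21 log units; within the scatter), so methylamino and ethylamino are not told apart here. Ethylamino in place of hydroxy gives a 9.5-fold higher number from compound 2 to compound 4 (0.98 log units; beyond the scatter) and methylamino in place of hydroxy gives a 5.8-fold higher number from compound 2 to compound 3 (0.76 log units; beyond the scatter), so both amines stand apart from the hydroxy of compound 2. No measurement shown accounts for either exchange.

From the compounds shown here alone, whether a longer chain, dimethylamino or a carboxylic acid here would come closer to compound 2 stays open. So does whether ethylamino reads the same on the core of compound 1.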